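Chlorine Added to an Anilide Series Stuck at the Limit

The compounds below may be only part of what the source reports. "The series", "measured", "known", "first", "only" and "open" are said of these compounds alone.

Compound 1 `COc1c(Br)cc(Br)cc1C(=O)Nc1ccccc1`: in an assay for inhibition of HSP60/HSP10 (Homo sapiens), with a stated time of 60 min (a higher number here means a weaker inhibitor, a lower number a stronger inhibitor), compound 1 gives > 100000 nM, which is a limit of the assay and not a number.
Compound 2 `O=C(Nc1ccccc1)c1cc(Br)cc(Br)c1`: compound 2 gives > 100000 nM, again only a limit.
Compound 3 `COc1ccc(Br)cc1C(=O)Nc1ccccc1`: compound 3 gives > 100000 nM, again only a limit.

Compound 1 therefore stands at the limit of > 100000 nM in this assay, at which 3 of the 3 values shown sit. The change to compound 4 `COc1c(Br)cc(Br)cc1C(=O)Nc1cccc(Cl)c1` is chloro in place of hydrogen on an aromatic carbon. Two measured steps start from compound 1: a step that the two limits leave unreadable from compound 1 to compound 2 and a step that the two limits leave unreadable from compound 1 to compound 3. Both run from one limit to another, so their size cannot be read, and neither concerns the ring that receives the chloro. No readable step bears on this change. Compound 4 is thus expected to give 100000 nM, within 30000 nM to 300000 nM. The step from compound 1 to compound 4 is estimated as a number no higher from compound 1 to compound 4 (the limit leaves the size open), none beyond the scatter, most likely another limit.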

Compound 4, half-maximal inhibitory concentration: > 100000 nM
Compound 4 was reported as a limit; the forecaster's own chance of this, stated with the estimate: 85%; the middle value lies on the limit itself.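

Going by these compounds, no new step can be read: compound 1 and compound 4 are both reported only as a limit, so the size of the change stays unknown. The compounds shown leave open whether any change to the shared core gives a true number in this assay at all.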